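Methyl in place of the oxime ether on the shared core

The source may report more compounds than this note shows. Statements on the series, on what has been measured and on what is new or still open speak of the compounds shown alone.

Compound 3 `CC/C(=N/OC)c1ccc2oc(CSc3nnc(CNc4ccccc4)n3CC)nc2c1` carries a group of 6 heavy atoms (4 carbon, 1 nitrogen, 1 oxygen; no ring) on an aromatic carbon of the shared core. In an assay on isolated protein for inhibition of long-chain fatty acid transport protein 1 (Mus musculus) (a lower number here means a stronger inhibitor, a higher number a weaker inhibitor), compound 3 gives only a limit, > 10000 nM, and no number. Compound 1 `CCc1ccc2oc(CSc3nnc(CNc4ccccc4)n3CC)nc2c1` carries ethyl at that place and gives 1800 nM in this assay. Compound 2 `CCn1c(CNc2ccccc2)nnc1SCc1nc2cc(C(=O)C(C)C)ccc2o1` carries isopropylcarbonyl there and gives 520 nM. The measured steps run a 3.5-fold lower number from compound 1 to compound 2 (0.54 log units; beyond the scatter), an at least 5.5-fold higher number from compound 1 to compound 3 (0.74 log units; beyond the scatter) and an at least 19-fold higher number from compound 2 to compound 3 (1.28 log units; beyond the scatter); the two steps toward compound 3 end at the limit of > 10000 nM in this assay, at which 1 of the 3 values shown sits, so the larger group marks the weak end of this small series.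

Compound 4 `CCn1c(CNc2ccccc2)nnc1SCc1nc2cc(C)ccc2o1` differs from compound 3 by one carbon atom in place of a group of 6 heavy atoms (4 carbon, 1 nitrogen, 1 oxygen; no ring), on an aromatic carbon. Methyl is a small alkyl group like the ethyl of compound 1, whose value of 1800 nM gives the nearest measured anchor. The step from compound 3 to compound 4 is therefore expected to be an at least 4.0-fold lower number from compound 3 to compound 4 (0.60 log units; beyond the scatter), a return from the limit toward a measurable number. Compound 4 is estimated at 2500 nM, with a range from 800 nM to 8000 nM.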

Compound 4, half-maximal inhibitory concentration: > 10000 nM
Compound 4: no number, only a limit; the forecaster's own chance of this, stated with the estimate: 15%; middle value at least 4.0-fold (0.60 log units) from the limit.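

In this assay compound 4, with methyl on the aromatic carbon, gives > 10000 nM, which is a limit of the assay and not a number. Cutting the group down to methyl therefore brings back no measurable value, and the gaps to the two measured compounds can still be read: an at least 5.5-fold higher number from compound 1 to compound 4 (0.74 log units; beyond the scatter), and an at least 19-fold higher number from compound 2 to compound 4 (1.28 log units; beyond the scatter). The step between compound 3 and compound 4 cannot be read, and a limit now appears with both the largest and the smallest group shown at this place, while ethyl and isopropylcarbonyl give numbers: the limit of > 10000 nM in this assay, at which 2 of the 4 values shown sit.

The compounds shown leave open whether a longer chain such as propyl, or an amine, would give a number here. They also leave open whether plain isopropyl, without the carbonyl, would match compound 2.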